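The compounds below may be only part of what the source reports. "The series", "measured", "known", "first", "only" and "open" are said of these compounds alone.

Series notes, cytotoxicity branch. In an ADME assay on Akata cells (Homo sapiens) for cytotoxicity, with a stated time of 7 days (a lower number here means that less compound is tolerated, a higher number that more compound is tolerated), compound 1 `CC(C)Nc1nc(N)nc2c1ncn2/C=C1/CC1(CO)CO` returns only a limit, > 24000 nM. Compound 2 `Nc1nc(N2CCCC2)c2ncn(/C=C3/CC3(CO)CO)c2n1` returns in this assay likewise only a limit, > 24000 nM. For the measured compounds named here, with both results capped, the one measured step, a step that the two limits leave unreadable from compound 1 to compound 2, cannot be sized, and the sole regularity in hand is the limit of > 24000 nM in this assay, at which 2 of the 2 values shown sit.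

Compound 3 `Nc1nc(SC2CCCC2)c2ncn(/C=C3/CC3(CO)CO)c2n1` is reached from compound 1 by cyclopentylsulfanyl in place of isopropylamino on an aromatic carbon. Going by the values given here, the measured step from compound 1 to compound 2 is the only one at the same position and it is unreadable, so no measured step bears on the new change with a readable size. Compound 1 itself stands at the cap, so the expectation for compound 3 in this assay rests on that cap alone. The expected step is a step that the limit leaves unreadable from compound 1 to compound 3, meaning no movement beyond the scatter, with the result again likely to come back as a limit rather than a number. Compound 3 is accordingly estimated at 30000 nM, within 10000 nM to 100000 nM.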

Compound 3, half-maximal cytotoxic concentration: > 20000 nM
Compound 3: a limit, no number; the forecaster's own chance of this, stated with the estimate: 70%; the middle value lies beyond the limit too.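

Compound 3 returns only a limit in this assay, as do compound 1 and compound 2, so neither of its steps to those two compounds can be read. Left open is whether isopropylamino, pyrrolidin-1-yl and cyclopentylsulfanyl on this aromatic carbon differ at all in half-maximal cytotoxic concentration, and where any of the three compounds would reach it.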